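Dichlorophenyl isomer step from compound 3 to compound 4

A few compounds are considered here, and "the series" means these few. Any claim that something is new, unique, unknown or untested is made for them only; others in the source may bear on it.

Values so far in an ADME assay on cells (Epithelial cell, Homo sapiens) for cytotoxicity, read by MTT assay, with a stated time of 24 h; a higher number here means that more compound is tolerated, a lower number that less compound is tolerated:
- compound 1 `CC(=O)OC[C@H]1O[C@@H](CC(=O)/C=C/c2cc(Cl)cc(Cl)c2O)[C@H](OC(C)=O)[C@@H](OC(C)=O)[C@@H]1OC(C)=O` gives "not determined" (no result reported)
- compound 2 `CCOc1ccc(/C=C/C(=O)C[C@@H]2O[C@H](COC(C)=O)[C@@H](OC(C)=O)[C@H](OC(C)=O)[C@H]2OC(C)=O)cc1` gives "not determined" (no result reported)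
- compound 3 `CC(=O)OC[C@H]1O[C@@H](CC(=O)/C=C/c2cc(Cl)cc(Cl)c2)[C@H](OC(C)=O)[C@@H](OC(C)=O)[C@@H]1OC(C)=O` gives 32.9 nM

Among the measured compounds shown here, compound 3 holds the only number in this assay, so it cannot yet be ranked against anything. Compound 4 `CC(=O)OC[C@H]1O[C@@H](CC(=O)/C=C/c2ccc(Cl)c(Cl)c2)[C@H](OC(C)=O)[C@@H](OC(C)=O)[C@@H]1OC(C)=O` is the next entry. The change is 3,4-dichlorophenyl in place of 3,5-dichlorophenyl on a double-bonded chain carbon bound to a double-bonded chain carbon, with 3,4-dichlorophenyl in place of 3,5-dichlorophenyl. For the measured compounds named here, no measured pair shows the size of such a step, so the expectation in this assay rests on compound 3 at 32.9 nM alone, with no direction and no step beyond the scatter. The expected change is a 1.1-fold higher number from compound 3 to compound 4 (0.03 log units; within the scatter) and remains an estimate. For compound 4 the estimated value is 35 nM, within an expected range of 11 nM to 110 nM.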

Compound 4, half-maximal cytotoxic concentration: 25.8 nM
Estimate against measurement, compound 4: 1.4-fold (0.13 log units) above, and the stated range covers the measured number.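

In this assay, among the compounds shown here, 3,4-dichlorophenyl in place of 3,5-dichlorophenyl on a double-bonded chain carbon bound to a double-bonded chain carbon gives a 1.3-fold lower number from compound 3 to compound 4 (0.11 log units; within the scatter), the first readable step at this position. Moving one chlorine around the ring therefore leaves the two dichlorophenyl isomers indistinguishable in this read-out. No available evidence bears on this result.

Compound 1 and compound 2 carry no number, so steps involving them cannot be read. From the compounds shown here alone, whether an amine or a carboxylic acid in place of the chlorines would shift the tolerated concentration beyond the scatter remains open.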